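The source may hold more compounds than are shown below. What is called first, only, known or untested is meant among the compounds shown, and "the series" means these compounds.

Values in an ADME assay on CHO cells (Cricetulus griseus) for cytotoxicity, read by MTT assay (a higher number here means that more compound is tolerated, a lower number that less compound is tolerated), for the compounds measured so far:
Compound 1 `CN1CCN(C2CCN(c3nccc4[nH]c(-c5ccc(F)c(F)c5)nc34)CC2)CC1` gives 5000 nM
Compound 2 `CN1CCN(C2CCN(c3nccc4[nH]c(-c5ccc(F)c(C(F)(F)F)c5)nc34)CC2)CC1` gives 4800 nM
Compound 3 `Fc1ccc(-c2nc3c(N4CCC(N5CCNCC5)CC4)nccc3[nH]2)cc1C(F)(F)F` gives 34000 nM

Compound 2 shares the low end of these numbers with compound 1, the two lying within the scatter of each other, while compound 3 stands clearly higher. The change under study leads to compound 4 `COC(=O)c1cccc(-c2nc3c(N4CCC(N5CCN(C)CC5)CC4)nccc3[nH]2)c1` and is 3-(methoxycarbonyl)phenyl in place of 4-fluoro-3-(trifluoromethyl)phenyl on an aromatic carbon with 3-(methoxycarbonyl)phenyl in place of 4-fluoro-3-(trifluoromethyl)phenyl on an aromatic carbon. Among the measured compounds shown here, the only measured change on this aromatic ring is a 1.0-fold lower number from compound 1 to compound 2 (0.02 log units; within the scatter) for trifluoromethyl in place of fluoro on an aromatic carbon, and it is the step that bears most directly. The larger measured step, a 7.1-fold higher number from compound 2 to compound 3 (0.85 log units; beyond the scatter) for hydrogen in place of methyl on an amine nitrogen in a ring, lies at another place, and compound 4 keeps that methyl, so it bears only on how far this series can move. For the measured compounds named here, no measured compound carries a carbonyl on this ring, so the range is kept wide. No step beyond the scatter is therefore expected in this assay and the estimated change is a 1.1-fold higher number from compound 2 to compound 4 (0.06 log units; within the scatter) in size. For compound 4 the expected value is 5500 nM with an estimated range from 2000 nM to 14000 nM in this read-out.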

Compound 4, half-maximal cytotoxic concentration: 34000 nM
The estimate for compound 4 lay 6.2-fold (0.79 log units) below the measured number, and the stated range ends below it.
By their numbers in this assay, from the lowest: compounds 2 and 1 (each within the scatter of the next); then compounds 3 and 4 (each within the scatter of the next).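

In this assay, the aryl group on the aromatic carbon of the five-membered ring does affect the number: there is a 7.1-fold higher number from compound 2 to compound 4 (0.85 log units; beyond the scatter) for 3-(methoxycarbonyl)phenyl in place of 4-fluoro-3-(trifluoromethyl)phenyl, and a 6.8-fold higher number from compound 1 to compound 4 (0.83 log units; beyond the scatter) for the same group in place of 3,4-difluorophenyl. The earlier change on this ring, a 1.0-fold lower number from compound 1 to compound 2 (0.02 log units; within the scatter), stayed within the scatter and exchanged one fluorinated aryl group for another, whereas the new group carries no fluorine and brings a carbonyl, and the change here is as large as a 7.1-fold higher number from compound 2 to compound 3 (0.85 log units; beyond the scatter) at the ring amine nitrogen. No measurement on hand bears on why the number moves with this exchange.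

With the whole aryl group exchanged in one step, the compounds shown do not separate the loss of fluoro and trifluoromethyl from the arrival of the methyl ester, and a plain phenyl, a carboxylic acid or a primary amide at this place would begin to tell these apart. As far as these compounds go, it also stays open whether hydrogen in place of methyl on the ring amine nitrogen would add to this step on the 3-(methoxycarbonyl)phenyl compound.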